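Notes on the step from compound 3 to compound 4

The compounds below may be only part of what the source reports. "The series", "measured", "known", "first", "only" and "open" are said of these compounds alone.

Three compounds carry measured numbers. Compound 1 `O=C1Nc2ccc(C(=O)c3ccco3)cc2/C1=C/c1cc(F)c(O)c(F)c1` gives 21% in an assay on HeLa cells for inhibition of Kinesin-like protein KIF15 (Homo sapiens), read by microscopy, with stated times of 2 s and 20 s, tested at 750 nM; on this read-out lower numbers stand for less inhibition and higher numbers for more inhibition at the one concentration tested (going by the name of the read-out). Compound 2 `O=C1Nc2ccc(C(=O)c3ccco3)cc2/C1=C/c1cc(F)c(O)c(Br)c1` gives 38% in this assay, the step being a number 17 percentage points higher from compound 1 to compound 2 (beyond the scatter). Compound 3 `Cc1cc(/C=C2\C(=O)Nc3ccc(C(=O)c4ccco4)cc32)cc(C)c1O` gives 9% in this assay and stands lowest of the three: a number 12 percentage points lower from compound 1 to compound 3 (beyond the scatter), and a number 29 percentage points lower from compound 2 to compound 3 (beyond the scatter).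

Compound 4 `O=C1Nc2ccc(C(=O)c3ccco3)cc2/C1=C/c1ccc(O)nc1` is not yet measured. It differs from compound 3 in one place: 6-hydroxypyridin-3-yl in place of 4-hydroxy-3,5-dimethylphenyl on a double-bonded chain carbon bound to a double-bonded ring carbon. Among the measured compounds shown here, no measured pair changes the group in this way, so the only steps that bear on it are the two ending at compound 3, both of modest size and both downward. The 6-hydroxypyridin-3-yl group of compound 4 resembles none of the groups on compound 1, compound 2 or compound 3 closely enough to fix a direction, so a step within the scatter or at most a small rise is expected, a number 6 percentage points higher from compound 3 to compound 4 (within the scatter). Compound 4 is therefore estimated at 15% in this assay, with a range from 0% to 35%.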

Compound 4, a percentage reported as inhibition, at one concentration (the size of the read-out at that concentration, not a potency): 26.5%
Compound 4: middle estimate off by 11.5 percentage points, on the low side; the measured number falls inside the stated range.
By their numbers in this assay, from the lowest: compound 3; then compounds 1 and 4 (each within the scatter of the next); then compound 2.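

In this assay, the place on a double-bonded chain carbon bound to a double-bonded ring carbon accepts an aromatic ring with a hetero atom, and the change to 6-hydroxypyridin-3-yl gives a number 17.5 percentage points higher from compound 3 to compound 4 (beyond the scatter), the first upward step away from the 4-hydroxy-3,5-dimethylphenyl group. The same group still gives a number 11.5 percentage points lower from compound 2 to compound 4 (beyond the scatter), while a number 5.5 percentage points higher from compound 1 to compound 4 (within the scatter) leaves it unseparated from the 3,5-difluoro-4-hydroxyphenyl group, although it has fewer heavy atoms than either. Nothing measured here bears on the reason for these steps.

The compounds shown do not separate the ring nitrogen of compound 4 from the absence of the two methyl groups of compound 3. As far as these compounds go, all of them keep a hydroxy group on the aromatic ring, so it remains open how an amine or a carboxylic acid in its place would read out.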